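Trimming the amide side chain: plasma half-life outlook

This account rests on a few compounds, and the source may have more. Where it says the series, first, only, none or still open, it means among the compounds named here.

Of the compounds shown here, two have so far been measured in an in vitro ADME assay on a cell-free system (plasma) for pharmacokinetics; on this read-out higher numbers stand for a longer-lived compound and lower numbers for a shorter-lived compound. Compound 1 `CCOC(=O)CCCN(C(=O)/C(C)=C/c1ccc(C(=O)Oc2ccc(C(=N)N)cc2)cc1)C(C(=O)OCC)C(=O)OCC` gives only a limit in this assay, < 0.0167 h, so no true number is known for it. For the measured compounds named here, compound 2 `CCOC(=O)CCCN(C(=O)/C(C)=C/c1ccc(C(=O)Oc2ccc(C(=N)N)cc2)cc1)C(C(=O)O)C(=O)OCC` gives 0.233 h in this assay, and this is the only real number available. Going by the values given here, the other value is the one already mentioned for compound 1, (the limit of < 0.0167 h in this assay, at which 1 of the 2 values shown sits). Among the compounds with values here, the single measured step, an at least 13-fold higher number from compound 1 to compound 2 (1.14 log units; beyond the scatter), is therefore large but rests on one limit and one number.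

Compound 3 `C=CCN(CCCC(=O)OCC)C(=O)/C(C)=C/c1ccc(C(=O)Oc2ccc(C(=N)N)cc2)cc1` differs from compound 2 in another part of the molecule: allyl in place of carboxy(ethoxycarbonyl)methyl on an amide-type nitrogen. The measured step from compound 1 to compound 2 concerns a different position and a different kind of change, so it does not directly bear on this one; it shows only that this assay can respond strongly to changes on the side chain of the shared core. Without a step at the same position, the expectation for compound 3 is no step beyond the scatter, expressed as a 1.3-fold higher number from compound 2 to compound 3 (0.11 log units; within the scatter). Compound 3 is estimated at 0.3 h in this assay, with a wide range from 0.05 h to 2 h.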

Compound 3, half-life: < 0.0167 h
Compound 3 gave a limit, no number (the forecaster's own chance of this, stated with the estimate: 10%); middle value at least 17-fold (1.25 log units) away from the limit.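

Swapping carboxy(ethoxycarbonyl)methyl for allyl on the amide-type nitrogen gives an at least 13-fold lower number from compound 2 to compound 3 (1.14 log units; beyond the scatter) in this assay, so this position, which the earlier step did not touch, also moves the read-out strongly. Of the three compounds shown, only compound 2 carries a free carboxy group, and it is also the only one with a real number, although three compounds are too few to call this a rule. Compound 3 gives only a limit, as does compound 1, so the series now has a single true measurement: the limit of < 0.0167 h in this assay, at which 2 of the 3 values shown sit.

Going by these compounds, the step from compound 1 to compound 3 cannot be read, as both ends are limits, and the true half-life of compound 3 remains unknown. On these data alone, it also remains open which part of the larger group matters, since the change removes the carboxy group and the ethoxycarbonyl group together; a simple carboxymethyl group on the amide-type nitrogen, or a carboxylic acid at the end of a longer chain there, would help to tell the two apart.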